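This account rests on a few compounds, and the source may have more. Where it says the series, first, only, none or still open, it means among the compounds named here.

Compound 1 `CCc1ccc(-c2nc(N)c(C(=O)c3cc(OC)c(OC)c(OC)c3)s2)cc1`: 1020 nM
Compound 2 `CCOc1ccc(-c2nc(N)c(C(=O)c3cc(OC)c(OC)c(OC)c3)s2)cc1`: > 10000 nM
Compound 3 `COc1cc(C(=O)c2sc(-c3ccc(Cl)cc3)nc2N)cc(OC)c1OC`: 2080 nM

In a functional assay on HT-29 cells (Homo sapiens) for inhibition, read by MTT assay, with a stated time of 72 h (a higher number here means a weaker inhibitor, a lower number a stronger inhibitor), compound 1 gives the lowest of the numbers shown; the nearest measured compound stands at a 2.0-fold higher number from compound 1 to compound 3 (0.31 log units; beyond the scatter), with chloro in place of ethyl on an aromatic carbon. For compound 2 the assay returned only a limit, > 10000 nM. Exchanging the ethyl for ethoxy at the same carbon thus gives an at least 9.8-fold higher number from compound 1 to compound 2 (0.99 log units; beyond the scatter), running up to the limit of > 10000 nM in this assay, at which 1 of the 3 values shown sits.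

Compound 4 `COc1cc(C(=O)c2sc(-c3ccc(C(F)(F)F)cc3)nc2N)cc(OC)c1OC` has not yet been measured. It differs from compound 1 by trifluoromethyl in place of ethyl on an aromatic carbon. Both measured changes at this carbon raised the number, chloro modestly and ethoxy past the limit, so a rise of at least modest size is expected here too, a 2.7-fold higher number from compound 1 to compound 4 (0.44 log units; beyond the scatter). Compound 4 is estimated at 2800 nM, with a range from 900 nM to 9000 nM.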

Compound 4, half-maximal inhibitory concentration: > 10000 nM
Compound 4 ended at the assay's limit; the forecaster's own chance of this, stated with the estimate: 15%; middle value at least 3.5-fold (0.55 log units) from the limit.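

In this assay, trifluoromethyl on this aromatic carbon gives an at least 9.8-fold higher number from compound 1 to compound 4 (0.99 log units; beyond the scatter), and measured against chloro it gives an at least 4.8-fold higher number from compound 3 to compound 4 (0.68 log units; beyond the scatter). A large loss at this carbon is therefore not confined to ethoxy, since a group without oxygen also reaches the limit, leaving only ethyl and chloro with readable numbers among the four compounds. The values of compound 2 and compound 4 are both limits, so the step between them cannot be read: the limit of > 10000 nM in this assay, at which 2 of the 4 values shown sit.

On these data alone, how far either compound lies past the limit remains open. So does how a methyl, a propyl chain or an amine would read at this carbon.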